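The source may hold more compounds than are shown below. What is called first, only, known or untested is meant among the compounds shown, and "the series" means these compounds.

Compound 1 `Cc1ccccc1COc1cc(O)c2c(=O)c(O)c(-c3ccccc3)oc2c1` and compound 2 `O=c1c(O)c(-c2ccccc2)oc2cc(OCc3ccc(Cl)cc3)cc(O)c12` share one core and differ only in the substituted ring on the benzyloxy chain. In an ADME assay on Huh-5-2 cells (Homo sapiens) for cytotoxicity, read by WST assay, with a stated time of 3 days (on this read-out lower numbers stand for higher toxicity in this test and higher numbers for lower toxicity in this test), compound 1 gives 17000 nM. Compound 2 reaches only a limit of this assay, > 100000 nM, as recorded in the limit of > 100000 nM in this assay, at which 1 of the 2 values shown sits. For the measured compounds named here, the step of an at least 5.8-fold higher number from compound 1 to compound 2 (0.76 log units; beyond the scatter) is thus the sole measured comparison. Compound 3 `O=c1c(O)c(-c2ccccc2)oc2cc(OCc3ccc(Br)cc3)cc(O)c12` carries bromo in place of chloro on an aromatic carbon. That measured step exchanged a whole aryl pattern, whereas here one halogen replaces another, so no step beyond the scatter is expected in this assay for compound 3; the estimate is 150000 nM, between 40000 nM and 500000 nM, meaning a step that the limit leaves unreadable from compound 2 to compound 3.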

Compound 3, half-maximal cytotoxic concentration: > 100000 nM
Compound 3: a limit, no number (the forecaster's own chance of this, stated with the estimate: 65%); the middle value is on the limit's open side.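

Compound 3 shows that the higher number seen with 4-chlorobenzyl is not confined to chloro: in this assay, 4-bromobenzyl in place of 2-methylbenzyl gives an at least 5.8-fold higher number from compound 1 to compound 3 (0.76 log units; beyond the scatter). The exchange of chloro for bromo on this aromatic carbon cannot be read, and no order can be given for compound 2 and compound 3, as both stand at a limit: the limit of > 100000 nM in this assay, at which 2 of the 3 values shown sit.

From the compounds shown here alone, what remains open is how far either compound lies past that limit, and whether an amine or a carboxylic acid at this place would lower the number.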